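Swapping the Aryl Group on the Pyrazole Nitrogen

The source may report more compounds than this note shows. Statements on the series, on what has been measured and on what is new or still open speak of the compounds shown alone.

In an assay on CHO-K1 cells for antagonist activity at transient receptor potential cation channel subfamily V member 1 (Homo sapiens), read by FLIPR and calcium flux, with a stated time of 6 min (on this read-out higher numbers stand for weaker inhibition and lower numbers for stronger inhibition), the three measured compounds span a narrow but resolved band. Compound 1 `Cn1ncc2c(NC(=O)NCc3cc(C(C)(C)C)nn3-c3cccc(Cl)c3)cccc21` gives 0.4 nM, compound 2 `O=C(NCc1cc(C(F)(F)F)nn1-c1cccc(C(F)(F)F)c1)Nc1cccc2[nH]ncc12` gives 1.3 nM, and compound 3 `O=C(NCc1cc(C(F)(F)F)nn1-c1ccc(C(F)(F)F)cc1)Nc1cccc2[nH]ncc12` gives 3.8 nM. Compound 3 therefore carries the highest number of the three, with compound 2 nearest and compound 1 furthest away. Among the measured compounds shown here, the one single-site step that can be read directly is a 2.9-fold higher number from compound 2 to compound 3 (0.47 log units; beyond the scatter), so moving the trifluoromethyl from the 3-position to the 4-position of the aryl ring on the aromatic nitrogen cost a modest amount of inhibition.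

Compound 4 `O=C(NCc1cc(C(F)(F)F)nn1-c1ccc(F)c(Cl)c1)Nc1cccc2[nH]ncc12` returns to the 3-position with a different pattern: 3-chloro-4-fluorophenyl in place of 4-(trifluoromethyl)phenyl on an aromatic nitrogen. This change bears on the measured step in that the substituent is again placed at the 3-position, as in compound 2 and, with a different core, in compound 1, where the numbers were lower than for compound 3. On that basis compound 4 is expected to recover some of the ground lost, an estimated step of a 2.5-fold lower number from compound 3 to compound 4 (0.40 log units; beyond the scatter). The estimate for compound 4 in this assay is 1.5 nM, with a range from 0.5 nM to 5 nM.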

Compound 4, inhibition constant: 0.6 nM
Estimate against measurement, compound 4: 2.5-fold (0.40 log units) above, and the stated range covers the measured number.
By their numbers in this assay, from the lowest: compounds 1 and 4 (each within the scatter of the next); then compound 2; then compound 3.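

In this assay, the change runs a 6.3-fold lower number from compound 3 to compound 4 (0.80 log units; beyond the scatter), so the loss seen on going to 4-(trifluoromethyl)phenyl is not only recovered on this aromatic nitrogen: 3-chloro-4-fluorophenyl also improves on 3-(trifluoromethyl)phenyl, with a 2.2-fold lower number from compound 2 to compound 4 (0.34 log units; beyond the scatter). This means the higher number of compound 3 cannot be read as a general penalty for any substituent at the ring's 4-position, since compound 4 carries fluorine there and still has a lower number than compound 2, although that comparison changes two substituents at once. No measurement available here explains why the 3-chloro-4-fluorophenyl group gives the lower number in this series.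

As far as these compounds go, the step from compound 2 to compound 4 cannot separate the contribution of the chlorine from that of the fluorine, so it remains open how 3-chlorophenyl or 4-fluorophenyl alone would read on this nitrogen. From the compounds shown here alone, it is also open whether the trend extends to a 3-methoxyphenyl group, or to a saturated ring such as cyclohexyl in place of the aryl group.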